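Thiophene in place of chlorophenyl: next step in the series

The source may report more compounds than this note shows. Statements on the series, on what has been measured and on what is new or still open speak of the compounds shown alone.

Three compounds share one core. Compound 1 `O=c1cc(-c2ccccc2)oc2ccc(OCCCCCCN3CCC(O)CC3)cc12` gives 121 nM in an assay on isolated protein (Cavia porcellus) with Sigma non-opioid intracellular receptor 1 (Homo sapiens) as the target, read by radioligand binding; on this read-out higher numbers stand for weaker inhibition and lower numbers for stronger inhibition. Compound 2 `O=c1cc(-c2ccccc2)oc2ccc(OCCCCCCN3CCCCC3)cc12` gives 54 nM in this assay, and compound 3 `O=c1cc(-c2ccccc2Cl)oc2ccc(OCCCCCCN3CCC(O)CC3)cc12` gives 29 nM in this assay. Compound 3 has the lowest number of the three; its gap to compound 2 lies within the scatter, so no order between those two can be claimed, while the step of a 4.2-fold lower number from compound 1 to compound 3 (0.62 log units; beyond the scatter) lies beyond the scatter. The other measured step, a 2.2-fold lower number from compound 1 to compound 2 (0.35 log units; beyond the scatter), concerns the saturated ring and does not touch the aromatic ring changed here.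

Compound 4 `O=c1cc(-c2cccs2)oc2ccc(OCCCCCCN3CCC(O)CC3)cc12` is not yet measured. The change is thiophen-2-yl in place of 2-chlorophenyl on an aromatic carbon. Within the data shown here, only one measured step bears on it, because a 4.2-fold lower number from compound 1 to compound 3 (0.62 log units; beyond the scatter) shows what the chloro contributed; compound 4 loses that chloro and gains a ring for which no measured comparison exists in this set. The expectation is therefore a modest rise in the number, partly undoing that step, with wide uncertainty on the new ring. Compound 4 is estimated at 80 nM, between 25 nM and 250 nM, an expected step of a 2.8-fold higher number from compound 3 to compound 4 (0.44 log units; beyond the scatter) in this assay.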

Compound 4, half-maximal inhibitory concentration: 232 nM
The estimate for compound 4 lay 2.9-fold (0.46 log units) below the measured number, and the stated range covers the measured number.
By their numbers in this assay, from the lowest: compounds 3 and 2 (each within the scatter of the next); then compounds 1 and 4 (each within the scatter of the next).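

In this assay, thiophen-2-yl in place of 2-chlorophenyl on the aromatic carbon next to the ring oxygen gives an 8.0-fold higher number from compound 3 to compound 4 (0.90 log units; beyond the scatter), so the low number of compound 3 does not carry over to this other aromatic ring. Thiophen-2-yl in place of phenyl at the same carbon gives a 1.9-fold higher number from compound 1 to compound 4 (0.28 log units; within the scatter), so these two rings cannot be told apart here, and of the three groups at this position only 2-chlorophenyl stands apart from the other two. No measurement at hand accounts for either step.

Open, from the compounds shown here alone, is whether the step of a 4.2-fold lower number from compound 1 to compound 3 (0.62 log units; beyond the scatter) belongs to chlorine itself or would appear with another group in its place, such as a fluoro, methyl or methoxy group on the phenyl ring, and whether a chloro on the thiophen-2-yl ring would give a similar step. Also open, going by these compounds, is whether the step of a 2.2-fold lower number from compound 1 to compound 2 (0.35 log units; beyond the scatter) on the saturated ring carries over to compounds bearing 2-chlorophenyl or thiophen-2-yl, and how a shorter chain in place of the hexyl linker would act.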